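The source may report more compounds than this note shows. Statements on the series, on what has been measured and on what is new or still open speak of the compounds shown alone.

Measured compounds:
Compound 1, `Cn1c(COc2cccc(C(=O)O)c2)nc2cnc(Oc3ccc4c(c3)CCC4)cc21`: 16.5 10^-6 cm/s
Compound 2, `Cn1c(COc2cccc(C(=O)O)c2)nc2ccc(Oc3cc(Cl)ccn3)cc21`: 10.3 10^-6 cm/s

In an ADME assay for permeability, using PAMPA, with a stated time of 4 h (on this read-out higher numbers stand for higher permeability and lower numbers for lower permeability), compound 1 gives 16.5 10^-6 cm/s. In this assay compound 2 gives 10.3 10^-6 cm/s. Of the two numbers, that of compound 2 is the lower one, yet its distance to compound 1 lies within the scatter of this assay, so the two compounds cannot be told apart on these data.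

Compound 3, `Cn1c(COc2cccc(C(=O)O)c2)nc2ccc(Oc3ccc(F)cn3)cc21`, is not yet measured. It differs from compound 2 in one place: 5-fluoropyridin-2-yl in place of 4-chloropyridin-2-yl on an oxygen on an aromatic ring. Among the compounds with values here, no pair of measured compounds in this set differs in a single place, so no step size can be read from them. The expected step from compound 2 to compound 3 in this assay is a 1.1-fold lower number from compound 2 to compound 3 (0.06 log units; within the scatter), which is not a change beyond the scatter. The estimate for compound 3 in this assay is 9 10^-6 cm/s, with a range from 5 10^-6 cm/s to 16 10^-6 cm/s.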

Compound 3, apparent permeability: 4.7 10^-6 cm/s
For compound 3 the middle estimate is 1.9-fold (0.28 log units) above the measured one; the measured number lies below the stated range.
By their numbers in this assay, from the lowest: compound 3; then compounds 2 and 1 (each within the scatter of the next).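

Within the data shown here, this is the first single-place step in the set, and it shows that the group on this oxygen matters in this assay: the change gives a 2.2-fold lower number from compound 2 to compound 3 (0.34 log units; beyond the scatter), a modest step but one beyond the scatter. The two groups match in everything counted, with the same number of heavy atoms, the same six-membered aromatic ring with one hetero atom, the same hydrogen-bond counts and no net charge, so those counts do not separate them. No measurement at hand accounts for the step.

The chlorine becomes fluorine and its place on the ring changes in the same step, so the compounds shown cannot tell these two changes apart. They also leave open how this position would read with an amine or a methoxy group on the pyridine ring in place of the halogen.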